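Imidazole Series: Swapping the Aryl Urea Terminus

The source may report more compounds than this note shows. Statements on the series, on what has been measured and on what is new or still open speak of the compounds shown alone.

Measured compounds:
Compound 1, `O=C(Nc1ccc(Oc2ccc(-c3nccs3)cc2)cc1)Nc1ccc(F)c(C(F)(F)F)c1`, in a functional assay on MDA-MB-231 cells (Homo sapiens) for inhibition, read by MTT assay and WST assay, with a stated time of 72 h, tested at 10 uM (on this read-out lower numbers stand for less inhibition of growth and higher numbers for more inhibition of growth at the one concentration tested), compound 1 gives 71.8%.
Compound 2, `O=C(Nc1ccc(Oc2ccc(-c3ncc[nH]3)cc2)cc1)Nc1ccc(Cl)c([N+](=O)[O-])c1`, in this assay compound 2 gives 3.36%.

Compound 2 stands lowest of the two numbers; its nearest neighbour is compound 1, whose value lies higher by a margin beyond the scatter. Among the measured compounds shown here, the two differ in more than one place, so no single step between them can be named.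

Compound 3, `O=C(Nc1ccc(Oc2ccc(-c3ncc[nH]3)cc2)cc1)Nc1ccc(F)c(C(F)(F)F)c1`, is not yet measured. It differs from compound 2 in one place: 4-fluoro-3-(trifluoromethyl)phenyl in place of 4-chloro-3-nitrophenyl on an amide-type nitrogen. For the measured compounds named here, the aryl group entering is the one carried by compound 1, while the rest of compound 3 is that of compound 2.

Since compound 1 reaches 71.8% with this same aryl group, an upward step is expected for compound 3, though its size is uncertain; the estimated step of a number 34.6 percentage points higher from compound 2 to compound 3 (beyond the scatter) goes up. Compound 3 is expected to give 38% in this assay, within 8% to 68%.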

Compound 3, percent growth inhibition at one concentration: 26.6%
For compound 3 the middle estimate is 11.4 percentage points above the measured one; the measured number falls inside the stated range.
By their numbers in this assay, from the lowest: compound 2; then compound 3; then compound 1.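

In this assay, the aryl group on the amide-type nitrogen matters with the 1H-imidazol-2-yl group in place: 4-fluoro-3-(trifluoromethyl)phenyl in place of 4-chloro-3-nitrophenyl gives a number 23.2 percentage points higher from compound 2 to compound 3 (beyond the scatter), a modest step. The other end of the molecule can now be read on its own as well: 1H-imidazol-2-yl in place of 1,3-thiazol-2-yl on an aromatic carbon gives a number 45.2 percentage points lower from compound 1 to compound 3 (beyond the scatter), a large step, so this aryl group alone does not carry the value of compound 1. Nothing given here accounts for either step.

As far as these compounds go, it remains open whether 4-chloro-3-nitrophenyl would behave the same way alongside 1,3-thiazol-2-yl, so it cannot be said whether the two changes simply add up. Also open, from the compounds shown here alone, is what an amine or a carboxylic acid on the aryl group would do at this position.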